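From benzamido to anilino on a shared core

The source may hold more compounds than are shown below. What is called first, only, known or untested is meant among the compounds shown, and "the series" means these compounds.

Of the compounds shown here, three sharing one core have been tested in a physicochemical assay for solubility, read by LC-MS, in phosphate buffer, with a stated time of 24 h, at pH 7.4 (a higher number here means a more soluble compound, a lower number a less soluble compound), so far. Compound 1 `Fc1ccc2c(c1CNc1ncc(Oc3ccccc3)c3nncn13)CCO2` gives 8000 nM with phenoxy, and compound 2 `CN(C(=O)c1ccccc1)c1cnc(NCc2c(F)ccc3c2CCO3)n2cnnc12` gives 280000 nM with benzoyl(methyl)amino. Compound 3 `O=C(Nc1cnc(NCc2c(F)ccc3c2CCO3)n2cnnc12)c1ccccc1` gives 2000 nM with benzamido, the lowest of the three numbers.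

Compound 4 `Fc1ccc2c(c1CNc1ncc(Nc3ccccc3)c3nncn13)CCO2` has phenyl in place of benzoyl on a nitrogen on an aromatic ring, so benzamido becomes anilino phenyl in place of benzoyl on a nitrogen on an aromatic ring in this change.

The closest guide is the modest step of a 4.0-fold lower number from compound 1 to compound 3 (0.60 log units; beyond the scatter) on replacing phenoxy, since compound 1 also lacks the carbonyl. The large step of a 140-fold lower number from compound 2 to compound 3 (2.15 log units; beyond the scatter) involved hydrogen in place of methyl on an amide-type nitrogen, which is not the change made here, so it offers little guidance.

A small rise is therefore expected, with the estimated step being a 2.0-fold higher number from compound 3 to compound 4 (0.30 log units; within the scatter) in this assay terms. For compound 4 the expected value is 4000 nM with an estimated range of 1200 nM to 14000 nM for now.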

Compound 4, solubility: 3000 nM
Beside the measured number, compound 4's estimate is 1.3-fold (0.12 log units) above it; measured number inside the range.
By their numbers in this assay, from the lowest: compounds 3 and 4 (each within the scatter of the next); then compound 1; then compound 2.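

In this assay, going from benzamido to anilino on the nitrogen on an aromatic ring gives a step within the scatter (a 1.5-fold higher number from compound 3 to compound 4 (0.18 log units; within the scatter)), so at this position, losing the carbonyl of benzoyl leaves no readable change in the number. Compound 4 also sits far from the methylated amide (a 93-fold lower number from compound 2 to compound 4 (1.97 log units; beyond the scatter)) and modestly apart from the phenoxy compound (a 2.7-fold lower number from compound 1 to compound 4 (0.43 log units; beyond the scatter)), so among these four compounds, only compound 2 stands out by a large step. No measurement shown here accounts for any of these steps.

From the compounds shown here alone, it remains open whether methyl on the anilino nitrogen would bring a large rise like the one seen with the benzoyl(methyl)amino group of compound 2. Going by these compounds, how a morpholine or a carboxylic acid on this aromatic carbon would read also remains unknown.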